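Estimating a methoxycarbonyl analogue of compound 3

A few compounds are considered here, and "the series" means these few. Any claim that something is new, unique, unknown or untested is made for them only; others in the source may bear on it.

Measured so far:
Compound 1 `C[S+]([O-])c1nc2ccccn2c(=N)c1S(=O)(=O)c1ccccc1`: 250 nM
Compound 2 `N=c1c(S(=O)(=O)c2ccccc2)c(NCCO)nc2ccccn12`: 42 nM
Compound 3 `CSc1nc2ccc(Cl)cn2c(=N)c1S(=O)(=O)c1ccccc1`: 28 nM

Of the compounds shown here, three sharing one core have been tested in an assay on HeLa cells for displacement of a labelled ligand from 5-hydroxytryptamine receptor 6 (Homo sapiens); a lower number here means a stronger inhibitor, a higher number a weaker inhibitor. Compound 3 gives the lowest number of the three; its gap to compound 2 lies within the scatter, whereas compound 1 stands well apart, with a number far higher than that of compound 3. Among the compounds with values here, the one single-site step measured, a 6.0-fold lower number from compound 1 to compound 2 (0.77 log units; beyond the scatter), concerns a change on a different aromatic carbon and so does not bear directly on the present change.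

Compound 4 `COC(=O)c1ccc2nc(SC)c(S(=O)(=O)c3ccccc3)c(=N)n2c1` differs from compound 3 as follows: methoxycarbonyl in place of chloro on an aromatic carbon. Within the data shown here, compound 1 and compound 3 differ at two places, so their values show only that the chloro-bearing analogue sits much lower. Among the measured compounds shown here, no measured step tells how the methoxycarbonyl group would behave at this place. Compound 4 is therefore expected to stay near compound 3, with a 1.4-fold higher number from compound 3 to compound 4 (0.15 log units; within the scatter) inside or only just beyond the scatter, and its estimated value in this assay is 40 nM, expected to lie between 10 nM and 160 nM.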

Compound 4, half-maximal inhibitory concentration: 470 nM
Compound 4: middle estimate off by 12-fold (1.07 log units), on the low side; the whole stated range lies below it.
By their numbers in this assay, from the lowest: compounds 3 and 2 (each within the scatter of the next); then compounds 1 and 4 (each within the scatter of the next).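

In this assay, the aromatic carbon two atoms from the ring nitrogen turns out to be sensitive to what it carries: methoxycarbonyl in place of chloro gives a 17-fold higher number from compound 3 to compound 4 (1.22 log units; beyond the scatter), a large step beyond the scatter. Within the data shown here, this is the first single-place step measured at this carbon, so it shows that the chloro group of compound 3 cannot be exchanged freely here, at least not for this larger group with 4 heavy atoms and 2 hydrogen-bond acceptors. No measurement at hand accounts for the size of this step.

Among these compounds, with only two groups compared at this carbon, it remains open which feature of the methoxycarbonyl group matters. A methyl group, a nitrile, a carboxylic acid or an amine here could help separate these features and show how far the trend extends.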